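Changing the Aryl Group on a Shared Nucleoside Core

This account rests on a few compounds, and the source may have more. Where it says the series, first, only, none or still open, it means among the compounds named here.

Compound 1 `OC[C@H]1O[C@@H](n2cnc3c(NCc4ccccc4F)ncnc32)[C@H](O)[C@@H]1O` — 4600 nM
Compound 2 `OC[C@H]1O[C@@H](n2cnc3c(NCc4ccc(Cl)c(Cl)c4)ncnc32)[C@H](O)[C@@H]1O` — 3800 nM

Both compounds were tested in a functional assay on CCRF-CEM cells (Homo sapiens) for antiproliferative activity, with a stated time of 72 h; a lower number here means a stronger inhibitor, a higher number a weaker inhibitor. Among the compounds with values here, compound 1 shows the higher of the two numbers, but its only neighbour is compound 2, and the step of a 1.2-fold lower number from compound 1 to compound 2 (0.08 log units; within the scatter) lies within the scatter, so the two cannot be told apart on potency. Within the data shown here, that step swaps one aryl group for another at the same place, and it is the single piece of evidence available for the kind of change considered next.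

Compound 3 `COc1cccc(CNc2ncnc3c2ncn3[C@@H]2O[C@H](CO)[C@@H](O)[C@H]2O)c1OC` has not yet been measured. Compared with compound 1 it carries 2,3-dimethoxyphenyl in place of 2-fluorophenyl on a saturated chain carbon bound to a nitrogen on an aromatic ring. Among the measured compounds shown here, because the one measured exchange at this place, a 1.2-fold lower number from compound 1 to compound 2 (0.08 log units; within the scatter), stayed within the scatter, the expectation for compound 3 is a step of about a 1.1-fold lower number from compound 1 to compound 3 (0.04 log units; within the scatter), that is, no change beyond the scatter in either direction. For the measured compounds named here, compound 3 is therefore estimated at 4200 nM, with a likely range from 1500 nM to 12000 nM; a wider range is kept since only one step informs this guess.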

Compound 3, half-maximal inhibitory concentration: > 166000 nM
Compound 3 was reported as a limit; the forecaster's own chance of this, stated with the estimate: 10%; middle value at least 39-fold (1.59 log units) from the limit.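

In this assay the result for compound 3 is a limit and not a number: the limit of > 166000 nM in this assay, at which 1 of the 3 values shown sits.

Even read as a limit, it shows that the aryl group at this place is not interchangeable, as the one earlier exchange, a 1.2-fold lower number from compound 1 to compound 2 (0.08 log units; within the scatter), might have suggested. Replacing either earlier aryl group with 2,3-dimethoxyphenyl gives an at least 36-fold higher number from compound 1 to compound 3 (1.55 log units; beyond the scatter), and likewise an at least 43-fold higher number from compound 2 to compound 3 (1.64 log units; beyond the scatter), so both steps lie far beyond the scatter. Among these three compounds, 2-fluorophenyl and 3,4-dichlorophenyl cannot be told apart, while 2,3-dimethoxyphenyl stands clearly apart from both, and this change on a saturated chain carbon bound to a nitrogen on an aromatic ring is enough on its own to separate compound 3 from the others.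

The compounds shown do not tell whether both methoxy groups are needed for this large step, or whether a phenyl ring carrying a single methoxy group, a hydroxyl group or an amine would behave like compound 3 or like compound 1. They also leave open how far compound 3 really lies from the other two, and why the step is so large.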